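The source may hold more compounds than are shown below. What is called first, only, known or untested is meant among the compounds shown, and "the series" means these compounds.

Measured so far:
Compound 1, `CC(C)(C)c1ccc(NC(=O)c2ccc(-c3ccccn3)cc2)cc1` — in a functional assay for antagonist activity at transient receptor potential cation channel subfamily V member 1 (Rattus norvegicus) (a higher number here means a weaker inhibitor, a lower number a stronger inhibitor), compound 1 gives 8 nM.
Compound 2, `CC(C)(C)c1ccc(NC(=O)c2ccc(-c3ncccc3NS(=O)(=O)c3ccccc3)cc2)cc1` — in this assay compound 2 gives 166 nM.
Compound 3, `CC(C)(C)c1ccc(NC(=O)c2ccc(-c3ncccc3C(=O)O)cc2)cc1` — in this assay compound 3 gives 560 nM.

Compound 3 stands at the highest number of the three, that is, it is the weakest inhibitor shown. Compound 4, `CC(C)(C)c1ccc(NC(=O)c2ccc(-c3ncccc3-c3ncc[nH]3)cc2)cc1`, differs from it in one place: 1H-imidazol-2-yl in place of carboxy on an aromatic carbon. For the measured compounds named here, two measured steps bear on this position. Adding a group there gave a 70-fold higher number from compound 1 to compound 3 (1.85 log units; beyond the scatter) and a 21-fold higher number from compound 1 to compound 2 (1.32 log units; beyond the scatter), and swapping one group for the other gave a 3.4-fold higher number from compound 2 to compound 3 (0.53 log units; beyond the scatter). Compound 3 thus carries the least favourable group seen here, and a new group at the same place is expected to move back toward compound 2, a change of a 4.7-fold lower number from compound 3 to compound 4 (0.67 log units; beyond the scatter). For compound 4 the estimate is 120 nM, with a range from 30 nM to 500 nM.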

Compound 4, half-maximal inhibitory concentration: 694 nM
Compound 4: middle estimate off by 5.8-fold (0.76 log units), on the low side; measured number above the stated range.
By their numbers in this assay, from the lowest: compound 1; then compound 2; then compounds 3 and 4 (each within the scatter of the next).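

In this assay, the 1H-imidazol-2-yl and carboxy groups cannot be told apart, with the swap giving a 1.2-fold higher number from compound 3 to compound 4 (0.09 log units; within the scatter), so this five-membered aromatic ring brings no gain over carboxy. The (phenylsulfonyl)amino group remains the better of the substituents, with a 4.2-fold higher number from compound 2 to compound 4 (0.62 log units; beyond the scatter), and hydrogen remains better still, with an 87-fold higher number from compound 1 to compound 4 (1.94 log units; beyond the scatter). All three groups shown at this place therefore give a clearly higher number than hydrogen.

Going by these compounds, whether a small group such as methyl or an amine at this place would stay closer to compound 1 remains open. No evidence here explains why these groups raise the number.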